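Series notes: from compound 2 to compound 3

The source may report more compounds than this note shows. Statements on the series, on what has been measured and on what is new or still open speak of the compounds shown alone.

In a functional assay on HEL cells (Homo sapiens) (a lower number here means that less compound is tolerated, a higher number that more compound is tolerated), compound 1 `Cc1cn([C@@H]2O[C@H](CO[Si](C)(C)C(C)(C)C)[C@@]3(OS(=O)(=O)C=C3NCC(N)=O)[C@H]2O[Si](C)(C)C(C)(C)C)c(=O)n(C)c1=O` gives 13500 nM and compound 2 `CCOC(=O)CNC(=O)NC1=CS(=O)(=O)O[C@@]12[C@@H](CO[Si](C)(C)C(C)(C)C)O[C@@H](n1cc(C)c(=O)n(C)c1=O)[C@@H]2O[Si](C)(C)C(C)(C)C` gives 13000 nM on the same scale. Compound 2 has only compound 1 for comparison, and the two values lie within the scatter of each other. Compound 3 `Cc1cn([C@@H]2O[C@H](CO[Si](C)(C)C(C)(C)C)[C@@]3(OS(=O)(=O)C=C3NCC(=O)C(=O)O)[C@H]2O[Si](C)(C)C(C)(C)C)c(=O)n(C)c1=O` is still unmeasured in this assay and carries (carboxycarbonyl)methyl in place of ((ethoxycarbonyl)methyl)carbamoyl on an amine nitrogen, counted as (carboxycarbonyl)methyl in place of ((ethoxycarbonyl)methyl)carbamoyl on an amine nitrogen in its difference from compound 2. Among the compounds with values here, one measured step bears on this, as it also exchanges the group on an amine nitrogen: a 1.0-fold lower number from compound 1 to compound 2 (0.02 log units; within the scatter) stays within the scatter. Within the data shown here, that single step is thin support, and no measured compound carries the (carboxycarbonyl)methyl group. No step beyond the scatter is therefore expected in this assay and no direction is favoured. The estimated change is a 1.1-fold higher number from compound 2 to compound 3 (0.03 log units; within the scatter) and stays within the scatter. For compound 3 the expected value is 14000 nM with a wide estimated span from 6000 nM to 35000 nM as its range.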

Compound 3, half-maximal cytotoxic concentration: 146000 nM
Compound 3: middle estimate off by 10-fold (1.02 log units), on the low side, outside the stated range (above it).
By their numbers in this assay, from the lowest: compounds 2 and 1 (each within the scatter of the next); then compound 3.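

In this assay the substituent on the amine nitrogen turns out to matter: the values of compound 1 and compound 2 lie within the scatter of each other, yet the series now shows an 11-fold higher number from compound 2 to compound 3 (1.05 log units; beyond the scatter) and an 11-fold higher number from compound 1 to compound 3 (1.03 log units; beyond the scatter). The narrower of these two changes is carboxy in place of amino on a carbonyl carbon, so a single exchange at the end of the substituent is enough to give a large step, while carbamoylmethyl and ((ethoxycarbonyl)methyl)carbamoyl do not separate from one another. Nothing available here accounts for the step.

From the compounds shown here alone, whether a methyl ester, or a longer chain ending in a carboxylic acid, would keep the higher number in this assay remains open. Also open, going by these compounds, is how much of the step belongs to the carboxy group itself and how much to the rest of the (carboxycarbonyl)methyl group, as these three compounds do not separate the two.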